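Swapping a chlorophenyl ring for a pyrrole ring

The source may report more compounds than this note shows. Statements on the series, on what has been measured and on what is new or still open speak of the compounds shown alone.

Two thiosemicarbazones sharing one core have been measured so far. Compound 1 `CC1=CC[C@H](C(C)(C)NC(=S)N/N=C/c2ccccc2O)CC1` carries a hydroxy group on its aromatic ring and, in a functional assay on NCI-H460 cells (Homo sapiens) for inhibition, read by sulforhodamine B assay, with a stated time of 48 h (on this read-out lower numbers stand for stronger inhibition of growth and higher numbers for weaker inhibition of growth), compound 1 gives 1900 nM. Within the data shown here, compound 2 `CC1=CC[C@H](C(C)(C)NC(=S)N/N=C/c2ccccc2Cl)CC1` carries a chloro group in the same spot; in this assay compound 2 gives 64500 nM, the highest of the two numbers seen, and the single one-place step, a 34-fold higher number from compound 1 to compound 2 (1.53 log units; beyond the scatter), is large. Compound 3 `CC1=CC[C@H](C(C)(C)NC(=S)N/N=C/c2ccc[nH]2)CC1` is not yet measured. It differs from compound 2 by 1H-pyrrol-2-yl in place of 2-chlorophenyl on a carbon with a double bond to nitrogen. Among the measured compounds shown here, no measured step shows exactly this exchange; the only step that bears on it is the change of the hydroxy group to a chloro group, where the hydroxy group, a hydrogen-bond donor, was far more potent, and the entering 1H-pyrrol-2-yl also brings one hydrogen-bond donor. Against that, the ring itself changes in size and composition, which no measured compound tests. The expectation is therefore a step of a 4.3-fold lower number from compound 2 to compound 3 (0.63 log units; beyond the scatter) from compound 2 to compound 3. Compound 3 is estimated at 15000 nM, with a range from 3000 nM to 80000 nM.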

Compound 3, concentration for 50% growth inhibition: 18000 nM
Compound 3: middle estimate off by 1.2-fold (0.08 log units), on the low side; measured number inside the range.
By their numbers in this assay, from the lowest: compound 1; then compound 3; then compound 2.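

In this assay, the exchange of 2-chlorophenyl for 1H-pyrrol-2-yl gives a 3.6-fold lower number from compound 2 to compound 3 (0.55 log units; beyond the scatter), so this place on the carbon with a double bond to nitrogen does not need a six-membered aromatic ring of carbon only, and a five-membered aromatic ring with a hetero atom can stand there with a lower number than compound 2 shows. The same ring does not reach the level set by the 2-hydroxyphenyl group, since the change from that group gives a 9.5-fold higher number from compound 1 to compound 3 (0.98 log units; beyond the scatter), so among these three compounds, having a hydrogen-bond donor on the ring does not by itself bring the number down to that of compound 1. No measurement at hand explains why either step has the size it has.

The compounds shown leave open how an amine or a methoxy group would compare with the hydroxy group in the spot it holds in compound 1. They also leave open whether the hydrogen on the ring nitrogen of 1H-pyrrol-2-yl matters, a question that a methyl group on that nitrogen would address.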